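Swapping the aryl group on the oxime chain of a nucleotide agonist

A few compounds are considered here, and "the series" means these few. Any claim that something is new, unique, unknown or untested is made for them only; others in the source may bear on it.

Three compounds share a triphosphate nucleotide core and differ only in the group at the end of the chain on the oxime oxygen. Compound 1 `O=C(O)CCCO/N=c1/ccn([C@@H]2O[C@H](COP(=O)(O)OP(=O)(O)OP(=O)(O)O)[C@@H](O)[C@H]2O)c(=O)[nH]1` carries a carboxy group there and in a functional assay on 1321-N1 cells for agonist activity at P2Y purinoceptor 4 (Homo sapiens), read by scintillation counting and inositol phosphate accumulation (a higher number here means that more compound is needed for the effect, a lower number that less compound is needed), gives 470 nM. Compound 2 `O=c1[nH]/c(=N\OCCCc2ccc(F)cc2)ccn1[C@@H]1O[C@H](COP(=O)(O)OP(=O)(O)OP(=O)(O)O)[C@@H](O)[C@H]1O` carries a 4-fluorophenyl group and in this assay gives 105 nM. Compound 3 `O=c1[nH]/c(=N\OCCCc2cccc([N+](=O)[O-])c2)ccn1[C@@H]1O[C@H](COP(=O)(O)OP(=O)(O)OP(=O)(O)O)[C@@H](O)[C@H]1O` carries a 3-nitrophenyl group and in this assay gives 95 nM, the lowest of the three numbers, though the difference a 1.1-fold lower number from compound 2 to compound 3 (0.04 log units; within the scatter) is within the scatter. Both aryl groups lowered the number relative to the carboxy group: a 4.5-fold lower number from compound 1 to compound 2 (0.65 log units; beyond the scatter) and a 4.9-fold lower number from compound 1 to compound 3 (0.69 log units; beyond the scatter).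

Compound 4 `COc1ccc(CCCO/N=c2/ccn([C@@H]3O[C@H](COP(=O)(O)OP(=O)(O)OP(=O)(O)O)[C@@H](O)[C@H]3O)c(=O)[nH]2)cc1` has not been measured. It differs from compound 3 by 4-methoxyphenyl in place of 3-nitrophenyl on a saturated chain carbon, three bonds along the chain from an oxygen. The two measured aryl groups gave numbers within the scatter of each other, so a third aryl group in the same place is expected to give a number close to that of compound 3. Compound 4 is therefore expected to give 110 nM, with a range from 45 nM to 270 nM. This expectation amounts to a 1.2-fold higher number from compound 3 to compound 4 (0.06 log units; within the scatter), a change not beyond the scatter.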

Compound 4, half-maximal effective concentration: 23 nM
Compound 4: middle estimate off by 4.8-fold (0.68 log units), on the high side, outside the stated range (below it).
By their numbers in this assay, from the lowest: compound 4; then compounds 3 and 2 (each within the scatter of the next); then compound 1.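

The aryl groups at this position are not interchangeable, even though the 3-nitrophenyl and 4-fluorophenyl groups of compound 3 and compound 2 gave values within the scatter of each other: in this assay, 4-methoxyphenyl gives a clear gain (a 4.1-fold lower number from compound 3 to compound 4 (0.62 log units; beyond the scatter)). Methoxy in place of fluoro on the same aromatic carbon, a single small change, is enough for a step of similar size (a 4.6-fold lower number from compound 2 to compound 4 (0.66 log units; beyond the scatter)). Against the carboxy group the gain is large (a 20-fold lower number from compound 1 to compound 4 (1.31 log units; beyond the scatter)), so the end of this chain can move the number much further than the first three compounds showed, and nothing available here accounts for the gain.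

Going by these compounds, it remains open whether an ethoxy, a hydroxyl or an amine on that aromatic carbon would match the methoxy. On these data alone, how a longer chain carrying the 4-methoxyphenyl group would read in this assay is also open.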